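Swapping the aryl group before a cytotoxicity reading

The source may report more compounds than this note shows. Statements on the series, on what has been measured and on what is new or still open speak of the compounds shown alone.

Three compounds sharing one core were tested in an ADME assay on HEL cells (Homo sapiens) for cytotoxicity; on this read-out lower numbers stand for higher toxicity in this test and higher numbers for lower toxicity in this test. Compound 1, `C/C(=N\NC(=O)COc1cccc2ccccc12)c1ccc(C#N)cc1Br`, gives 20 ug/mL in this assay. Compound 3, `O=C(COc1cccc2ccccc12)N/N=C/c1ccccc1[N+](=O)[O-]`, gives 20 ug/mL. Compound 2, `COc1ccc(OC)c(/C=N/NC(=O)COc2cccc3ccccc23)c1`, returns only a limit of this assay, >= 20 ug/mL, so no exact number is known for it. On these readings compound 1 stands level with compound 3 at the digits shown, within the usual scatter. The remaining reading sits at the limit of >= 20 ug/mL in this assay, at which 1 of the 3 values shown sits.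

Compound 4, `C/C(=N\NC(=O)COc1cccc2ccccc12)c1ccc(O)cc1`, has not been measured. It differs from compound 1 in one place: 4-hydroxyphenyl in place of 2-bromo-4-cyanophenyl on a carbon with a double bond to nitrogen. Within the data shown here, no step between two measured compounds shows how such a change moves this read-out, so there is no measured anchor for its size. The two numbers that do exist, for compound 1 and compound 3, fall at the same value although their aryl groups differ, and the third reading stands at a limit. The expected step is therefore small, no change at the digits printed from compound 1 to compound 4 (within the scatter), with no change beyond the scatter the most likely outcome, though a somewhat less toxic reading cannot be ruled out. Compound 4 is expected to give about 20 ug/mL in this assay, within a range from 10 ug/mL to 50 ug/mL.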

Compound 4, minimum cytotoxic concentration: 20 ug/mL
For compound 4 middle estimate and measured number coincide at the digits printed; low and high end bracket the measured number.
By their numbers in this assay, from the lowest: compounds 1, 3 and 4 (each within the scatter of the next).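

Among these compounds, this is the only measured step at this position in this assay, and it reads no change at the digits printed from compound 1 to compound 4 (within the scatter). The swap is not a minor edit: 2-bromo-4-cyanophenyl, with its bromine and nitrile, leaves, and 4-hydroxyphenyl enters, bringing a hydrogen-bond donor where the group that left had none. Even so, the read-out does not tell these two aryl groups apart on a carbon with a double bond to nitrogen, although this finding covers this one pair and nothing wider.

Compound 2 gives only a limit and not a number: the limit of >= 20 ug/mL in this assay, at which 1 of the 4 values shown sits. Still open, from the compounds shown here alone, is whether a group of a different kind at this position, such as an amine or a carboxylic acid in place of the aromatic ring, would move the reading in this assay beyond the scatter.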